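A few compounds are considered here, and "the series" means these few. Any claim that something is new, unique, unknown or untested is made for them only; others in the source may bear on it.

Compound 1, `COc1cccc(OC)c1N1C(=O)CSC1c1cccc(C(=O)NCCCCc2ccccc2)c1`, was tested in a functional assay on SJSA-1 cells (Homo sapiens) for inhibition, read by CCK-8 assay, with a stated time of 72 h, tested at 1 uM; on this read-out higher numbers stand for more inhibition at the one concentration tested (going by the name of the read-out) and lower numbers for less inhibition. In this assay compound 1 gives 72%. Going by the values given here, the only other compound measured there, compound 2, `O=C(NCCCCc1ccccc1)c1cccc(C2OCC(=O)N2c2cccc(F)c2)c1`, gives 32% in this assay. Compound 1 thus stands highest of the two numbers, and compound 2 lies below it by a gap that is beyond the usual scatter of repeated measurements. Among the compounds with values here, compounds 1 and 2 differ at more than one place, so their two values show only that the two compounds behave differently in this assay; nothing further can be drawn from that pair.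

Compound 3, `COc1ccc(F)cc1N1C(=O)CSC1c1cccc(C(=O)NCCCCc2ccccc2)c1`, has not yet been measured in this assay. It differs from compound 1 in one place: 5-fluoro-2-methoxyphenyl in place of 2,6-dimethoxyphenyl on an amide-type nitrogen in a ring. Within the data shown here, no step between measured compounds carries this same change, so the expectation rests on compound 1 alone. The change is expected to lower the reading slightly, and the step is estimated at a number 12 percentage points lower from compound 1 to compound 3 (beyond the scatter), a size at the edge of the usual scatter. Compound 3 is therefore expected to give about 60% in this assay, with a range from 35% to 80%.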

Compound 3, a percentage reported as inhibition, at one concentration (the size of the read-out at that concentration, not a potency): 76%
Compound 3: middle estimate off by 16 percentage points, on the low side, and the stated range covers the measured number.
By their numbers in this assay, from the lowest: compound 2; then compounds 1 and 3 (each within the scatter of the next).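

With 5-fluoro-2-methoxyphenyl in place of 2,6-dimethoxyphenyl on the amide-type nitrogen in the ring, the reading in this assay comes out a number 4 percentage points higher from compound 1 to compound 3 (within the scatter), so the two groups cannot be told apart on this read-out. Compound 1 alone could not show whether the high reading depended on 2,6-dimethoxyphenyl, but compound 3 shows that, on the shared core, this exact group is not required at this position, since compound 3 gives 76% at the one concentration tested. Nothing shown explains why this exchange leaves the reading within the usual scatter.

The single step alters two features of the aromatic ring at once, so the compounds shown leave open what the added fluorine and the removed methoxy group each contribute, and whether one change offsets the other. They also leave open how far this position extends beyond these two groups, for instance whether an unsubstituted phenyl, a 2-methoxyphenyl, or a phenyl carrying a dimethylamino group or a carboxylic acid would keep the reading, and whether a result at this single concentration would carry over to a full measure of potency.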